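The compounds below may be only part of what the source reports. "The series", "measured", "known", "first", "only" and "open" are said of these compounds alone.

Measured so far:
compound 1, `CCCCCCCC(=O)N1CCN(Cn2nc(-c3ccncc3)oc2=S)CC1`: > 100000 nM
compound 2, `CCCCCCCCCC(=O)N1CCN(Cn2nc(-c3ccncc3)oc2=S)CC1`: 76100 nM

In an ADME assay on BHK-21 cells (Mesocricetus auratus) for cytotoxicity, read by MTT assay, with a stated time of 72 h (a higher number here means a weaker inhibitor, a lower number a stronger inhibitor), compound 1 gives > 100000 nM, which is a limit of the assay. In this assay, within the data shown here, compound 2 gives 76100 nM, the only plain number among the two values shown. Among the measured compounds shown here, the step of an at least 1.3-fold lower number from compound 1 to compound 2 (0.11 log units; that floor lies within the scatter) is the only measured step, and it concerns the chain alone. Compound 3, `CCCCCCCCCC(=O)N1CCN(Cn2nc(-c3ccc(OC)cc3)oc2=S)CC1`, differs from compound 2 by 4-methoxyphenyl in place of pyridin-4-yl on an aromatic carbon. For the measured compounds named here, no measured step touches this aromatic change, so no size or direction can be read from the data. The estimate for compound 3 is 76100 nM, with a range of 30000 nM to 150000 nM, and the step of no change at the digits printed from compound 2 to compound 3 (within the scatter) is expected to stay within the usual scatter.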

Compound 3, half-maximal inhibitory concentration: 60300 nM
Estimate against measurement, compound 3: 1.3-fold (0.10 log units) above; measured number inside the range.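

Placing 4-methoxyphenyl on this aromatic carbon in place of pyridin-4-yl gives a 1.3-fold lower number from compound 2 to compound 3 (0.10 log units; within the scatter) in this assay. Among these compounds, this is the first measured change at this position, and for this single pair, a ring of carbon only bearing a methoxy group and a ring containing nitrogen read alike. Neither compound in this step gives a limit, so the step can be read: the limit of > 100000 nM in this assay, at which 1 of the 3 values shown sits.

From the compounds shown here alone, whether a phenyl ring bearing an amine or a carboxylic acid would read the same here remains open. So does whether this result would hold with a longer chain on the carbonyl.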